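Swapping the Amide Substituent on a Shared Core

The source may hold more compounds than are shown below. What is called first, only, known or untested is meant among the compounds shown, and "the series" means these compounds.

For the measured compounds named here, compound 2 `Cc1c(C(=O)N[C@H]2C[C@@](C)(O)C2)c(-c2cccc(N3CCN(c4ccc(NS(=O)(=O)c5ccc(N[C@H](CCN(C)C)CSc6ccccc6)c([N+](=O)[O-])c5)cc4)CC3)c2)c(-c2ccc(Cl)cc2)n1C` gives 7.5 nM in an assay on isolated protein for binding affinity to Apoptosis regulator Bcl-2 (Homo sapiens), read by fluorescence polarization, with a stated time of 2 h (a lower number here means a stronger inhibitor, a higher number a weaker inhibitor), the upper of the two numbers measured so far, though only within the scatter of the other. Going by the values given here, its one neighbour, compound 1 `CNC(=O)c1c(-c2cccc(N3CCN(c4ccc(NS(=O)(=O)c5ccc(N[C@H](CCN(C)C)CSc6ccccc6)c([N+](=O)[O-])c5)cc4)CC3)c2)c(-c2ccc(Cl)cc2)n(C)c1C`, gives 5 nM in this assay, and the step of a 1.5-fold higher number from compound 1 to compound 2 (0.18 log units; within the scatter) lies within the scatter, so the two compounds cannot be told apart. Compound 3 `Cc1c(C(=O)NS(C)(=O)=O)c(-c2cccc(N3CCN(c4ccc(NS(=O)(=O)c5ccc(N[C@H](CCN(C)C)CSc6ccccc6)c([N+](=O)[O-])c5)cc4)CC3)c2)c(-c2ccc(Cl)cc2)n1C` has not yet been measured. It differs from compound 2 in one place: methylsulfonyl in place of 3-hydroxy-3-methylcyclobutyl on an amide-type nitrogen. Among the compounds with values here, the single measured step, which also changes the group on the amide-type nitrogen, is the only one that bears on this change, and it shows no movement beyond the scatter. With no other guide, a small step is expected for a 1.1-fold higher number from compound 2 to compound 3 (0.03 log units; within the scatter), in no set direction. Compound 3 is therefore estimated at 8 nM in this assay, with a range from 3 nM to 25 nM.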

Compound 3, half-maximal inhibitory concentration: 0.9 nM
Estimate against measurement, compound 3: 8.9-fold (0.95 log units) above, outside the stated range (below it).
By their numbers in this assay, from the lowest: compound 3; then compounds 1 and 2 (each within the scatter of the next).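

At this position on the amide-type nitrogen, the earlier pair hinted that the group could be exchanged freely, but in this assay methylsulfonyl gives an 8.3-fold lower number from compound 2 to compound 3 (0.92 log units; beyond the scatter) and a 5.6-fold lower number from compound 1 to compound 3 (0.74 log units; beyond the scatter) as its two steps. The position is therefore not indifferent to what sits on this nitrogen: methyl and 3-hydroxy-3-methylcyclobutyl cannot be told apart, while methylsulfonyl stands clearly apart from both. Nothing measured here explains why the methanesulfonamido group gives the lower number. The compounds shown leave open whether this gain belongs to sulfonyl groups in general or to methylsulfonyl alone, a question that phenylsulfonyl or cyclopropylsulfonyl on the same nitrogen would address. They also leave open whether a carboxylic acid in place of the whole methanesulfonamido group would give a similar number.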